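A few compounds are considered here, and "the series" means these few. Any claim that something is new, unique, unknown or untested is made for them only; others in the source may bear on it.

Measured so far in an assay on BTI cells for inhibition of Amine oxidase [flavin-containing] B (Homo sapiens), read by fluorescence, with a stated time of 20 min, tested at 1 uM; on this read-out higher numbers stand for more inhibition at the one concentration tested (going by the name of the read-out) and lower numbers for less inhibition:
- compound 1, `C#CCNC1c2ccccc2OCC1(C)C`: 11.6%
- compound 2, `C#CCN(Cc1ccccc1)C1c2cccc(OC)c2OCC1(C)C`: 14.7%

Both numbers sit low on the inhibition scale, and compound 2 stands with compound 1 inside the scatter of this assay, so the pair shows no separation that can be read. Among the compounds with values here, no step between measured compounds is available here.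

Compound 3, `C#CCN(Cc1ccccc1)C1c2ccccc2OCC1(C)C`, is not yet measured in this assay. Relative to compound 2 the change is hydrogen in place of methoxy on an aromatic carbon. Within the data shown here, the only bearing the measured pair gives is that compound 1, which also carries hydrogen at the corresponding place, yields 11.6%, close to compound 2.

The step from compound 2 to compound 3 in this assay is therefore expected to stay within the scatter, a number 1.7 percentage points lower from compound 2 to compound 3 (within the scatter), with no clear direction. Compound 3 is estimated at 13%, with a range from 3% to 25%.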

Compound 3, a percentage reported as inhibition, at one concentration (the size of the read-out at that concentration, not a potency): 2.9%
Beside the measured number, compound 3's estimate is 10.1 percentage points above it; the whole stated range lies above it.
By their numbers in this assay, from the lowest: compounds 3, 1 and 2 (each within the scatter of the next, the first and the last beyond it).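

In this assay, within the data shown here, the methoxy on the aromatic carbon gives the first readable single change: hydrogen in place of methoxy gives a number 11.8 percentage points lower from compound 2 to compound 3 (beyond the scatter), so with the benzyl on the amine nitrogen held constant, this position is not indifferent to the change. Benzyl in place of hydrogen on an amine nitrogen gives a number 8.7 percentage points lower from compound 1 to compound 3 (within the scatter), so that change cannot be read as an effect in this assay. No measurement available here accounts for the methoxy step.

Whether the step is particular to methoxy stays open, with hydroxyl, fluorine or ethoxy on the same aromatic carbon not among the compounds shown. Also open, from the compounds shown here alone, is whether methoxy at this position would give a similar step on the core of compound 1, with hydrogen on the amine nitrogen.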